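Acyl azide to carbamate on the shared core

A few compounds are considered here, and "the series" means these few. Any claim that something is new, unique, unknown or untested is made for them only; others in the source may bear on it.

Compound 3 `COc1ccc2c(c1)[n+]([O-])c(C(=O)N=[N+]=[N-])c(C)[n+]2[O-]` gives 83.9% in a functional assay on Ehrlich cells (Mus musculus) for cytotoxicity, read by trypan blue exclusion, with a stated time of 2 h, tested at 10 ug/mL (a lower number here means a stronger effect, a higher number a weaker effect of the compound at the concentration tested), the lowest of the three numbers: compound 1 `N#Cc1c(N)[n+]([O-])c2ccc(Cl)cc2[n+]1[O-]` gives 97.3% and compound 2 `Cc1c(C(=O)N=[N+]=[N-])[n+]([O-])c2cc(Cl)ccc2[n+]1[O-]` gives 98%. For the measured compounds named here, the only single-point step among the measured compounds, a number 14.1 percentage points lower from compound 2 to compound 3 (beyond the scatter), concerns the aromatic substituent and not the side chain.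

Compound 4 `COc1ccc2c(c1)[n+]([O-])c(NC(=O)OC(C)C)c(C)[n+]2[O-]` differs from compound 3 by a group of 7 heavy atoms (4 carbon, 1 nitrogen, 2 oxygen; no ring) in place of a group of 5 heavy atoms (1 carbon, 3 nitrogen, 1 oxygen; no ring), on an aromatic carbon. Going by the values given here, no measured step alters this group, so the numbers give no direct guide for the size or direction of the change; the working expectation is a number 1.1 percentage points higher from compound 3 to compound 4 (within the scatter), a step not beyond the scatter. Compound 4 is therefore estimated at 85% in this assay, with a range from 68% to 98%.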

Compound 4, a percentage reported as activity, at one concentration (the size of the read-out at that concentration, not a potency): 99%
For compound 4 the middle estimate is 14 percentage points below the measured one, and the stated range ends below it.
By their numbers in this assay, from the lowest: compound 3; then compounds 1, 2 and 4 (each within the scatter of the next).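

In this assay, placing (isopropoxycarbonyl)amino on this aromatic carbon next to the ring nitrogen gives a number 15.1 percentage points higher from compound 3 to compound 4 (beyond the scatter) and shows that this position, not only the aromatic substituent, moves the read-out. With the methoxy group kept, the stronger effect of compound 3 does not carry over to the carbamate. No evidence on the reason for this step is available.

As far as these compounds go, it remains open how an amine or a carboxylic acid on this carbon would read. From the compounds shown here alone, a longer chain in place of the isopropyl group also remains open.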